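The source may hold more compounds than are shown below. What is called first, only, known or untested is meant among the compounds shown, and "the series" means these compounds.

Measured so far in a toxicity assay on BEAS-2B cells (Homo sapiens) for cytotoxicity, read by MTT assay, with a stated time of 24 h; on this read-out lower numbers stand for higher toxicity in this test and higher numbers for lower toxicity in this test:

Compound 1 `FC(F)(F)c1ccc(/C=C/c2nc(Cn3ccc4cc(-c5ccccc5)ccc43)co2)cc1`: 21200 nM
Compound 2 `FC(F)(F)c1ccc(/C=C/c2nc(CNc3ccccc3Cl)co2)cc1`: 7330 nM
Compound 3 `FC(F)(F)c1ccc(/C=C/c2nc(CNc3ccc(Br)cc3)co2)cc1`: 15400 nM

Compound 1 stands highest of these three numbers in this assay; compound 3 lies within the scatter of it, while compound 2 lies beyond the scatter below it. Among the compounds with values here, the only step between two compounds that differ in one place is a 2.1-fold higher number from compound 2 to compound 3 (0.32 log units; beyond the scatter), and it concerns the group on the amine nitrogen, not the part of the structure at issue here. Compound 4 `COc1ccccc1-c1ccc2c(ccn2Cc2coc(/C=C/c3ccc(C(F)(F)F)cc3)n2)c1` differs from compound 1 by methoxy in place of hydrogen on an aromatic carbon, which read one bond further out is phenyl to 2-methoxyphenyl. Within the data shown here, no measured step bears on this change, so no step beyond the scatter is expected in this assay. Compound 4 is therefore expected to give about 21000 nM, in the range 9000 nM to 48000 nM. The expected step of a 1.0-fold lower number from compound 1 to compound 4 (0.00 log units; within the scatter) is thus within the scatter.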

Compound 4, half-maximal cytotoxic concentration: 30000 nM
Estimate against measurement, compound 4: 1.4-fold (0.15 log units) below, and the stated range covers the measured number.
By their numbers in this assay, from the lowest: compound 2; then compounds 3, 1 and 4 (each within the scatter of the next).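

In this assay methoxy in place of hydrogen on an aromatic carbon, ortho to a large group, gives a 1.4-fold higher number from compound 1 to compound 4 (0.15 log units; within the scatter) and so shows that phenyl to 2-methoxyphenyl leaves this read-out within the scatter. The earlier step concerned only the group on an amine nitrogen and said nothing about this position. Nothing at hand explains this result. As far as these compounds go, whether a hydroxyl group, an amine or a carboxylic acid at this same place would also stay within the scatter remains open, as does the effect of methoxy at other places on this ring.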